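Amide-to-urea swap on the piperazine of compound 1

The source may report more compounds than this note shows. Statements on the series, on what has been measured and on what is new or still open speak of the compounds shown alone.

Measured so far:
compound 1, `COc1ccc(-c2cnc3nc(N)nc(N4CCN(C(=O)COc5ccccc5)CC4)c3n2)cc1OC`: 4 nM
compound 2, `CCOc1nc(N)nc2ncc(-c3ccc(C#N)cc3)nc12`: > 10000 nM
compound 3, `CCOc1nc(N)nc2ncc(-c3ccc(F)c(F)c3)nc12`: > 10000 nM

Among the measured compounds shown here, in a functional assay on cells (T-cell, Homo sapiens) for inhibition (on this read-out lower numbers stand for stronger inhibition and higher numbers for weaker inhibition), compound 1 gives 4 nM and is the only compound of the three with a numerical value. Compound 2 is reported only as a limit of this assay, > 10000 nM. Compound 3 likewise is reported only as a limit, > 10000 nM. For the measured compounds named here, both therefore sit at the limit of > 10000 nM in this assay, at which 2 of the 3 values shown sit, so no measured step connects any pair here, and compound 1 stands alone as the reference point for the series.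

The next compound, compound 4, `COc1ccc(-c2cnc3nc(N)nc(N4CCN(C(=O)Nc5cccc(C)c5)CC4)c3n2)cc1OC`, keeps the core and the piperazine of compound 1 and changes only the acyl group: (3-methylphenyl)amino in place of phenoxymethyl on a carbonyl carbon, that is, (phenoxymethyl)carbonyl becomes (3-methylphenyl)carbamoyl. Nothing measured tells how the potency of compound 1 depends on this group; the two limit compounds differ from compound 1 elsewhere and give no guidance.

Expectation: the change from compound 1 to compound 4 is expected to stay roughly within the scatter, with a step of a 1.5-fold higher number from compound 1 to compound 4 (0.18 log units; within the scatter) in this assay. Compound 4 is estimated at 6 nM, with a range from 1.5 nM to 25 nM.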

Compound 4, half-maximal inhibitory concentration: 7 nM
For compound 4 the middle estimate is 1.2-fold (0.07 log units) below the measured one; low and high end bracket the measured number.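

In this assay, placing (3-methylphenyl)amino in place of phenoxymethyl on a carbonyl carbon gives a 1.8-fold higher number from compound 1 to compound 4 (0.24 log units; within the scatter), so compound 1 and compound 4 cannot be told apart on this read-out. Among the compounds shown here, this is the first measured step at this position, and it shows that this one exchange of the amide of compound 1 for the urea of compound 4 leaves the read-out within the usual scatter, with a six-membered aromatic ring of carbon and 8 heavy atoms present in both groups. Nothing measured here explains why the two compounds read alike, since the only available observation concerns the assay limit and does not bear on this pair.

From the compounds shown here alone, it remains open whether this position needs an aromatic ring at all, which a short alkyl chain, a primary amine or a carboxylic acid on the carbonyl carbon would test. Also open, going by these compounds, is what the methyl of (3-methylphenyl)amino contributes, which the unsubstituted phenylamino group or a chloro group in its place would show.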